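Inactive Alcohols and Ethers, and a Benzyl Ether to Come

A few compounds are considered here, and "the series" means these few. Any claim that something is new, unique, unknown or untested is made for them only; others in the source may bear on it.

Compound 1 `COc1ccc(C(O)(Cc2ccc(C)cc2)c2cccc3ccccc23)c(OC)c1OC`, compound 2 `C=CCC(O)(c1ccc(OC)c(OC)c1OC)c1cccc2ccccc12` and compound 3 `C=CCOC(c1ccc(OC)c(OC)c1OC)c1cccc2ccccc12` are all tested in a functional assay on HCT-116 cells (Homo sapiens) for inhibition, read by sulforhodamine B assay, with a stated time of 48 h; on this read-out lower numbers stand for stronger inhibition and higher numbers for weaker inhibition. In this assay compound 1 reaches only a limit, > 20000 nM. Compound 2 likewise gives only a limit, > 20000 nM. Compound 3 also gives only a limit, > 20000 nM. The change 4-methylphenyl in place of vinyl on a saturated chain carbon, two bonds along the chain from two aromatic carbons and an oxygen on a saturated carbon therefore yields a step that the two limits leave unreadable from compound 2 to compound 1, because every value shown sits at the limit of > 20000 nM in this assay, at which 3 of the 3 values shown sit.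

Compound 4 `COc1ccc(C(OCc2ccc(C)cc2)c2cccc3ccccc23)c(OC)c1OC` differs from compound 3 by 4-methylphenyl in place of vinyl on a saturated chain carbon bound to an oxygen on a saturated carbon. The difference between the cores of compound 2 and compound 3 is not broken down here. The change to compound 4 is the same kind of change as that to compound 1, yet the place differs: in compound 1 it sits two bonds along the chain from two aromatic carbons and an oxygen on a saturated carbon, while in compound 4 the carbon is bound to an oxygen on a saturated carbon.

Compound 4 is expected to give about 30000 nM. The step expected is a step that the limit leaves unreadable from compound 3 to compound 4, estimated to be small, resting on compound 1 remaining at a limit with > 20000 nM.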

Compound 4, half-maximal inhibitory concentration: > 20000 nM
Compound 4: only a limit was reported; the forecaster's own chance of this, stated with the estimate: 85%; the middle value does not contradict the limit.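

No step can be read from compound 3 to compound 4, as both stop at a limit: the limit of > 20000 nM in this assay, at which 4 of the 4 values shown sit.

The compounds shown leave open how strongly any of them inhibits, and whether 4-methylphenyl in place of vinyl changes anything.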